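This account rests on a few compounds, and the source may have more. Where it says the series, first, only, none or still open, it means among the compounds named here.

In an ADME assay on microsomes from liver (Rattus norvegicus) for metabolic stability (on this read-out higher numbers stand for a longer-lived compound and lower numbers for a shorter-lived compound), compound 1 (`Cn1nc2c(=O)n(CC3(O)CCN(Cc4ccc(-c5cnco5)cc4Cl)CC3)cnc2c1-c1ccc(CN)cc1`) gives 3.85 h, the highest of the three numbers in hand, above compound 3 (`Cn1nc2c(=O)n(CC3(O)CCN(Cc4ccc(-c5ccco5)cc4Cl)CC3)cnc2c1-c1ccc(CNCCO)cc1`) at 1.52 h and compound 2 (`Cn1nc2c(=O)n(CC3(O)CCN(Cc4ccc(-c5ccco5)cc4Cl)CC3)cnc2c1-c1ccc(CNC=O)cc1`) at 0.55 h. Compound 4 (`Cn1nc2c(=O)n(CC3(O)CCN(Cc4ccc(-c5ccc(C(=O)O)o5)cc4Cl)CC3)cnc2c1-c1ccc(CN)cc1`) differs from compound 1 in one place: 5-carboxyfuran-2-yl in place of 1,3-oxazol-5-yl on an aromatic carbon. Going by the values given here, the only measured single change, a 2.8-fold higher number from compound 2 to compound 3 (0.44 log units; beyond the scatter), is modest and concerns an amine nitrogen, so it bears only weakly on this swap, and no measured step tests the swap directly. With no direction favoured, the estimated change is a 1.0-fold higher number from compound 1 to compound 4 (0.02 log units; within the scatter), and no step beyond the scatter is expected. For compound 4 the expected half-life is 4 h, with an estimated range of 1.5 h to 10 h.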

Compound 4, half-life: 1.25 h
Compound 4: the middle estimate sits 3.2-fold (0.51 log units) above what was measured; measured number outside the range, below it.
By their numbers in this assay, from the lowest: compound 2; then compounds 4 and 3 (each within the scatter of the next); then compound 1.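

In this assay, the aromatic carbon para to a large group proves sensitive to its substituent: 5-carboxyfuran-2-yl in place of 1,3-oxazol-5-yl gives a 3.1-fold lower number from compound 1 to compound 4 (0.49 log units; beyond the scatter), where the earlier step concerned only an amine nitrogen. The half-life therefore depends on the group held at this position as well. Nothing measured here gives a reason for this step.

The compounds shown leave open whether the five-membered aromatic ring or the carboxylic acid accounts for the step. They also leave open how a methyl ester or a primary amide in place of that acid would read in this assay.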